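From Aminophenyl to Dichlorophenyl: an Untested Cytotoxicity Step

The source may report more compounds than this note shows. Statements on the series, on what has been measured and on what is new or still open speak of the compounds shown alone.

Compound 1 `COc1cc(-c2cc(/C=C/C(=O)c3ccc(N)cc3)[nH]n2)cc(OC)c1OC` gives 83% in a functional assay on HOP-62 cells (Homo sapiens) for cytotoxicity, read by sulforhodamine B assay, with a stated time of 48 h, tested at 0.01 uM (a higher number here means a weaker effect of the compound at the concentration tested, a lower number a stronger effect), the lower of the two numbers recorded so far. Compound 2 `COc1ccc(-c2cc(/C=C/C(=O)c3ccc(OC)c(OC)c3)[nH]n2)cc1` gives 97% in this assay, a higher number that lies beyond the usual scatter. Compound 3 `COc1cc(-c2cc(/C=C/C(=O)c3ccc(Cl)c(Cl)c3)[nH]n2)cc(OC)c1OC` has not yet been measured; it differs from compound 1 in one place: 3,4-dichlorophenyl in place of 4-aminophenyl on a carbonyl carbon. No pair of measured compounds shows what such a change does in this assay, so the step from compound 1 to compound 3 is expected to stay within the scatter, shown as a number 5 percentage points higher from compound 1 to compound 3 (within the scatter). Compound 3 is therefore estimated at 88%, with a range from 72% to 102%.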

Compound 3, a percentage reported as activity, at one concentration (the size of the read-out at that concentration, not a potency): 99%
For compound 3 the middle estimate is 11 percentage points below the measured one; measured number inside the range.
By their numbers in this assay, from the lowest: compound 1; then compounds 2 and 3 (each within the scatter of the next).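

In this assay, 3,4-dichlorophenyl in place of 4-aminophenyl on a carbonyl carbon gives a number 16 percentage points higher from compound 1 to compound 3 (beyond the scatter), the first step read at this position. With the rest of compound 1 held fixed, the group on this carbonyl carbon can alone move the read-out beyond the scatter, toward a weaker effect at the concentration tested. The one swap removes the amine and adds both chlorines, so the compounds shown do not tell which of these changes carries the step. An unsubstituted phenyl on the same carbonyl carbon would separate the two. No measurement at hand gives a reason for the step.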